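The source may hold more compounds than are shown below. What is called first, only, known or untested is meant among the compounds shown, and "the series" means these compounds.

Measured so far:
compound 1 `OC[C@H]1O[C@@H](n2cnc3c(NCc4ccccc4)nccc32)C[C@@H]1O` — in a functional assay on the whole organism (Pleural cavity) with Rattus norvegicus as the target (on this read-out lower numbers stand for an effect already at smaller amounts and higher numbers for an effect only at larger amounts of compound), compound 1 gives > 9 mg/kg, which is a limit of the assay and not a number.
compound 2 `OC[C@H]1OC(n2cnc3c(Nc4ccccc4)nccc32)[C@H](O)[C@@H]1O` — in this assay compound 2 gives > 9 mg/kg, again a limit and not a number.

Compound 2 therefore stands at the limit of > 9 mg/kg in this assay, at which 2 of the 2 values shown sit, with no number of its own. Compound 3 `OC[C@H]1OC(n2cnc3c(NCc4ccccc4)nccc32)[C@H](O)[C@@H]1O` differs from compound 2 by benzyl in place of phenyl on a nitrogen on an aromatic ring. Within the data shown here, no step between measured compounds is available, so no direction can be drawn from the data; a limit once more is the likeliest outcome. Compound 3 is expected at 15 mg/kg, within 6 mg/kg to 40 mg/kg. This corresponds to an expected step that the limit leaves unreadable from compound 2 to compound 3.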

Compound 3, dose for half-maximal effect: > 9 mg/kg
Compound 3: only a limit was reported; the forecaster's own chance of this, stated with the estimate: 70%; the middle value is on the limit's open side.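

No step can be read between compound 2 and compound 3, since both values are limits and not numbers: the limit of > 9 mg/kg in this assay, at which 3 of the 3 values shown sit.

The compounds shown leave open whether benzyl in place of phenyl changes anything in this assay, and at what dose any of them gives a half-maximal effect.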